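The source may hold more compounds than are shown below. What is called first, only, known or untested is meant among the compounds shown, and "the series" means these compounds.

Measured so far in an assay on isolated protein for inhibition of DNA topoisomerase 1 (Homo sapiens), with a stated time of 15 min; a higher number here means a weaker inhibitor, a lower number a stronger inhibitor: compound 1 `CNC(=O)c1cn(Cc2ccc(-c3ccccc3)cc2)c2c(OC)c(N3CC[C@@H](CN)C3)c(F)cc2c1=O` with 82100 nM; compound 2 `COc1c(N2CC[C@@H](CN)C2)c(F)cc2c(=O)c(C(=O)NO)cn(Cc3ccc(-c4ccccc4)cc3)c12` with 35900 nM.

Compound 2 holds the lowest of the two numbers in this assay; the nearest neighbour is compound 1, and the move is a 2.3-fold lower number from compound 1 to compound 2 (0.36 log units; beyond the scatter), a modest step, hydroxy in place of methyl on an amide-type nitrogen.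

Compound 3 `COC(=O)c1cn(Cc2ccc(-c3ccccc3)cc2)c2c(OC)c(N3CC[C@@H](CN)C3)c(F)cc2c1=O` is not yet measured. It differs from compound 2 by methoxy in place of hydroxyamino on a carbonyl carbon. Within the data shown here, the only measured step that bears on this position is the one from compound 1 to compound 2, which was modest. Compound 3 gives up the hydroxyamino group and its two donors for a methoxy group, so the change reverses the direction of that step and goes somewhat further. A weaker result than compound 2 is therefore expected, of a size comparable to or a little beyond that step, the estimated move being a 2.5-fold higher number from compound 2 to compound 3 (0.40 log units; beyond the scatter).

For compound 3 in this assay the expected value is 90000 nM, with a range from 30000 nM to 300000 nM.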

Compound 3, half-maximal inhibitory concentration: 71400 nM
Estimate against measurement, compound 3: 1.3-fold (0.10 log units) above, and the stated range covers the measured number.
By their numbers in this assay, from the lowest: compounds 2, 3 and 1 (each within the scatter of the next, the first and the last beyond it).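

In this assay, methoxy in place of hydroxyamino on the carbonyl carbon gives a 2.0-fold higher number from compound 2 to compound 3 (0.30 log units; within the scatter), so this exchange, which leaves no hydrogen-bond donors in the entering group, cannot be told from repeat noise. Methoxy in place of methylamino gives a 1.1-fold lower number from compound 1 to compound 3 (0.06 log units; within the scatter), so these two groups cannot be told apart here, and an amide-type nitrogen is not shown to be required at this position; only the step between the hydroxyamino and methylamino compounds remains beyond the scatter. No measurement available explains these numbers.

Still open, going by these compounds, is whether a carboxylic acid or an unsubstituted carboxamide on this carbonyl carbon would separate from compound 3 by more than the scatter. A longer alkoxy chain, such as ethoxy or isopropoxy, is also untested among the compounds shown, as is any group giving a much lower number.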